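Shrinking the Amide Substituent of Compound 2

This account rests on a few compounds, and the source may have more. Where it says the series, first, only, none or still open, it means among the compounds named here.

Compound 1, `CC(NC(=O)c1cccc(-c2ccc(NC(=O)Nc3ccc(Cl)c(C(F)(F)F)c3)cc2)c1)c1ccccc1`: 5670 nM
Compound 2, `O=C(CCc1ccc(NC(=O)Nc2ccc(Cl)c(C(F)(F)F)c2)cc1)NC1CCC1`: a limit of the assay, > 50000 nM
Compound 3, `CC1CN(C(=O)/C=C/c2ccc(NC(=O)Nc3ccc(Cl)c(C(F)(F)F)c3)cc2)CC(C)O1`: 45900 nM

Of the compounds shown here, three on a shared core have been tested in a functional assay on HepG2 cells (Homo sapiens) for inhibition, read by MTT assay, with a stated time of 120 h; on this read-out lower numbers stand for stronger inhibition and higher numbers for weaker inhibition. Compound 2 reaches only (the limit of > 50000 nM in this assay, at which 1 of the 3 values shown sits), so its result is a limit rather than a number. Compound 3 also gives a high number in this assay, while compound 1 gives a lower one. Compound 4, `CNC(=O)CCc1ccc(NC(=O)Nc2ccc(Cl)c(C(F)(F)F)c2)cc1`, differs from compound 2 in one place: methyl in place of cyclobutyl on an amide-type nitrogen. Among the measured compounds shown here, since compound 2 stands at the limit, no measured step shows what this change does. The step is expected to be none beyond the scatter, a step that the limit leaves unreadable from compound 2 to compound 4. Compound 4 is therefore expected at 60000 nM, within 20000 nM to 200000 nM, most probably reported again as a limit.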

Compound 4, half-maximal inhibitory concentration: 21000 nM
Compound 4: middle estimate off by 2.9-fold (0.46 log units), on the high side; low and high end bracket the measured number.
By their numbers in this assay, from the lowest: compound 1; then compound 4; then compound 3. At a limit, above all of these: compound 2.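

Methyl in place of cyclobutyl on the amide-type nitrogen gives an at least 2.3-fold lower number from compound 2 to compound 4 (0.37 log units; beyond the scatter) in this assay. Among the compounds shown here, this is the first sign that the read-out responds to the group at this position, which the earlier compounds could not show. The result for compound 2 is a limit and not a number, so the step has a lower bound but no measured size: the limit of > 50000 nM in this assay, at which 1 of the 4 values shown sits.

With only these two groups compared at this nitrogen, no trend can be drawn. The compounds shown leave open what ethyl, cyclopropyl or the bare amide hydrogen would give there.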